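Chloro replacement on the acylguanidine core: compound 4

The source may report more compounds than this note shows. Statements on the series, on what has been measured and on what is new or still open speak of the compounds shown alone.

Measured so far in a functional assay for inhibition of sodium/hydrogen exchanger (Oryctolagus cuniculus); on this read-out higher numbers stand for weaker inhibition and lower numbers for stronger inhibition:
- compound 1 `Cc1cc(Cl)c(S(C)(=O)=O)cc1C(=O)N=C(N)N`: 25 nM
- compound 2 `Cc1cc(-c2ccc(Cl)cc2Cl)c(S(C)(=O)=O)cc1C(=O)N=C(N)N`: 42 nM
- compound 3 `CCCSc1cc(C)c(C(=O)N=C(N)N)cc1S(C)(=O)=O`: 6.8 nM

Compound 1 stands second highest of the three numbers in this assay. Its nearest neighbour is compound 2, reached by a 1.7-fold higher number from compound 1 to compound 2 (0.23 log units; within the scatter), a step that stays within the scatter. Its furthest is compound 3, reached by a 3.7-fold lower number from compound 1 to compound 3 (0.57 log units; beyond the scatter), a modest step beyond the scatter. Between the two substituted compounds the change is a 6.2-fold lower number from compound 2 to compound 3 (0.79 log units; beyond the scatter).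

Compound 4 `Cc1cc(Sc2ccccc2Cl)c(S(C)(=O)=O)cc1C(=O)N=C(N)N` is the next one to be tested. Relative to compound 1 the difference is (2-chlorophenyl)sulfanyl in place of chloro on an aromatic carbon. For the measured compounds named here, two measured steps bear on this. The propylsulfanyl step a 3.7-fold lower number from compound 1 to compound 3 (0.57 log units; beyond the scatter) shows that a sulfanyl-linked group at this carbon can lower the number modestly. The aryl step a 1.7-fold higher number from compound 1 to compound 2 (0.23 log units; within the scatter) shows that a chlorinated phenyl ring at the same carbon leaves the number within the scatter of compound 1. Compound 4 combines a sulfur link with a chlorinated phenyl ring, so a step somewhere between these two outcomes is expected: a small decrease, or none beyond the scatter.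

For compound 4 the expected value in this assay is 15 nM, with a range of 5 nM to 45 nM, which means an expected step of a 1.7-fold lower number from compound 1 to compound 4 (0.22 log units; within the scatter).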

Compound 4, half-maximal inhibitory concentration: 14 nM
Estimate against measurement, compound 4: 1.1-fold (0.03 log units) above; low and high end bracket the measured number.
By their numbers in this assay, from the lowest: compound 3; then compounds 4, 1 and 2 (each within the scatter of the next, the first and the last beyond it).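

In this assay, the carbon ortho to the methylsulfonyl group takes (2-chlorophenyl)sulfanyl in place of chloro with a 1.8-fold lower number from compound 1 to compound 4 (0.25 log units; within the scatter), so a sulfur-linked aromatic ring leaves the number within the scatter of the chloro compound. The sulfur link alone does not set the number, since what sits on the sulfur counts, with a 2.1-fold higher number from compound 3 to compound 4 (0.31 log units; beyond the scatter) for 2-chlorophenyl in place of propyl; the swap of the directly attached ring for the sulfur-linked one gives a 3.0-fold lower number from compound 2 to compound 4 (0.48 log units; beyond the scatter), but that change alters the link and the chlorine pattern together, so neither can be credited alone. Nothing at hand explains why these steps take the sizes they do.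

Open, as far as these compounds go, is how far the sulfur link itself matters at this carbon, as an ether oxygen or an amine in its place would show against the same 2-chlorophenyl ring. Also open, from the compounds shown here alone, is what a longer chain such as hexyl on the sulfur, or a phenyl ring without chlorine there, would do to the number.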